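This account rests on a few compounds, and the source may have more. Where it says the series, first, only, none or still open, it means among the compounds named here.

Compound 2 `FC(F)(F)c1ccc(-c2csc(N3N=C(c4ccc(N5CCCCC5)cc4)CC3c3ccc(Cl)cc3)n2)cc1` is one of a pair sharing the same core; the other, compound 1 `Fc1ccc(-c2csc(N3N=C(c4ccc(N5CCCCC5)cc4)CC3c3ccc(Cl)cc3)n2)cc1`, carries fluoro where compound 2 carries trifluoromethyl. In a functional assay on MCF7 cells (Homo sapiens) for antiproliferative activity, read by MTT assay, with a stated time of 72 h (a higher number here means a weaker inhibitor, a lower number a stronger inhibitor), compound 1 gives 23100 nM, and in this assay compound 2 gives 23700 nM. For the measured compounds named here, the single step that joins them, a 1.0-fold higher number from compound 1 to compound 2 (0.01 log units; within the scatter), changes nothing beyond the scatter, so the two numbers sit side by side and neither compound can be called stronger or weaker than the other on this evidence.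

Compound 3 `Cc1ccc(-c2csc(N3N=C(c4ccc(N5CCCCC5)cc4)CC3c3ccc(Cl)cc3)n2)cc1` takes the next step from compound 2: methyl in place of trifluoromethyl on an aromatic carbon. Going by the values given here, the only step that bears on this position is the one from compound 1 to compound 2, which left the number where it was, and it is the sole guide available; nothing measured speaks directly about methyl at this position. On that basis compound 3 is expected to give a number close to that of compound 2, with the step of a 1.0-fold lower number from compound 2 to compound 3 (0.01 log units; within the scatter) estimated to stay within the scatter. The estimate for compound 3 in this assay is 23000 nM, with a range from 10000 nM to 52000 nM.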

Compound 3, half-maximal inhibitory concentration: > 100000 nM
Compound 3: a limit, no number (the forecaster's own chance of this, stated with the estimate: 5%); middle value at least 4.3-fold (0.63 log units) away from the limit.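

In this assay compound 3 gives > 100000 nM, which is a limit of the assay and not a number. The position is therefore not indifferent to what it carries: the change to methyl makes an at least 4.2-fold higher number from compound 2 to compound 3 (0.62 log units; beyond the scatter), and the comparison with fluoro makes an at least 4.3-fold higher number from compound 1 to compound 3 (0.63 log units; beyond the scatter), whereas the exchange of fluoro for trifluoromethyl, a 1.0-fold higher number from compound 1 to compound 2 (0.01 log units; within the scatter), had shown no change beyond the scatter. The agreement of the first two compounds thus did not extend to every small group on this aromatic carbon, and of the three compounds shown, only the one bearing methyl stands at the limit: the limit of > 100000 nM in this assay, at which 1 of the 3 values shown sits.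

From the compounds shown here alone, how far past the limit compound 3 actually lies stays open, so both new steps give only a minimum size. Also open, going by these compounds, is whether chloro, methoxy or an amine on the same aromatic carbon would sit with fluoro and trifluoromethyl or with methyl, and so whether methyl is an isolated case among such groups.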